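The source may report more compounds than this note shows. Statements on the series, on what has been measured and on what is new or still open speak of the compounds shown alone.

In a functional assay on LoVo cells (Homo sapiens) for inhibition, read by MTT assay, with a stated time of 24 h (on this read-out lower numbers stand for stronger inhibition and higher numbers for weaker inhibition), compound 1 `CC1(C)[C@H]2CC[C@]1(C)N(Cc1cn(-c3ccc(C#N)cc3)nn1)C(=O)C2` gives 90 nM, and compound 2 `CC1(C)[C@H]2CC[C@]1(C)N(Cc1cn(-c3ccccc3C#N)nn1)C(=O)C2` gives 140 nM. Among the measured compounds shown here, the only step measured so far, a 1.6-fold higher number from compound 1 to compound 2 (0.19 log units; within the scatter), leaves these two compounds within the scatter of each other, so compound 2 stands level with compound 1. Compound 3 `CC1(C)[C@H]2CC[C@]1(C)N(Cc1cn(-c3ccc(Cl)cc3)nn1)C(=O)C2` differs from compound 2 in one place: 4-chlorophenyl in place of 2-cyanophenyl on an aromatic nitrogen. For the measured compounds named here, the one step that bears on this change, a 1.6-fold higher number from compound 1 to compound 2 (0.19 log units; within the scatter), moved the group between ring positions without a change beyond the scatter, and nothing measured speaks to chlorine itself. For compound 3 the expected outcome is a 1.4-fold lower number from compound 2 to compound 3 (0.15 log units; within the scatter), no more than scatter, and its estimated value in this assay is 100 nM (range 40 nM to 250 nM).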

Compound 3, half-maximal inhibitory concentration: 160 nM
For compound 3 the middle estimate is 1.6-fold (0.20 log units) below the measured one; the measured number falls inside the stated range.
By their numbers in this assay, from the lowest: compounds 1, 2 and 3 (each within the scatter of the next).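

Chlorine now has a measurement of its own: chloro in place of cyano on an aromatic carbon gives a 1.8-fold higher number from compound 1 to compound 3 (0.25 log units; within the scatter), and 4-chlorophenyl in place of 2-cyanophenyl gives a 1.1-fold higher number from compound 2 to compound 3 (0.06 log units; within the scatter). In this assay, neither swap moves the number beyond the scatter, so this position on the aromatic nitrogen accepts either 4-chlorophenyl or a cyanophenyl group with no measurable difference. No available evidence accounts for this result. Still open, going by these compounds, is whether an amine or a carboxylic acid on the phenyl ring would move the number beyond the scatter.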